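Moving a Methoxy Group Around a Small Fused Core

A few compounds are considered here, and "the series" means these few. Any claim that something is new, unique, unknown or untested is made for them only; others in the source may bear on it.

Compound 1 `O=c1[nH]c2ccccc2oc1=O` has the highest of the two numbers recorded so far: in a functional assay with Rattus norvegicus as the target (on this read-out higher numbers stand for weaker inhibition and lower numbers for stronger inhibition), compound 1 gives 42000 nM. Going by the values given here, its only measured neighbour, compound 2 `COc1cccc2[nH]c(=O)c(=O)oc12`, gives 7000 nM in this assay, a change of a 6.0-fold lower number from compound 1 to compound 2 (0.78 log units; beyond the scatter). Compound 3 `COc1ccc2oc(=O)c(=O)[nH]c2c1` differs from compound 1 by methoxy in place of hydrogen on an aromatic carbon. The same kind of group enters at a different place than in compound 2, so that measured step is only a rough guide; a modest move towards stronger inhibition is expected. Compound 3 is therefore estimated at 15000 nM, within 5000 nM to 45000 nM, an expected step of a 2.8-fold lower number from compound 1 to compound 3 (0.45 log units; beyond the scatter).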

Compound 3, half-maximal inhibitory concentration: 15000 nM
The estimate for compound 3 equals the measured number at the digits printed, and the stated range covers the measured number.
By their numbers in this assay, from the lowest: compound 2; then compound 3; then compound 1.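

On this carbon, meta to a fused ring and para to a fused ring, methoxy in place of hydrogen gives a 2.8-fold lower number from compound 1 to compound 3 (0.45 log units; beyond the scatter) in this assay. The lower number seen with compound 2 is therefore not confined to one place on the ring, since compound 2 and compound 3 carry methoxy at different carbons and both stand below compound 1. Nothing available explains this drop at either place. The compounds shown leave open whether an amine, a carboxylic acid or a longer chain on this carbon would lower the number further or raise it.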